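Adding Chlorine to the Phenyl of a Limit Compound

A few compounds are considered here, and "the series" means these few. Any claim that something is new, unique, unknown or untested is made for them only; others in the source may bear on it.

compound 1 `Cc1cc(S(=O)(=O)Nc2nc3ccsc3c(=O)n2Cc2ccccc2)c(S)cc1Cl` gives 14200 nM in a functional assay on A498 cells (Homo sapiens) for inhibition; on this read-out lower numbers stand for stronger inhibition of growth and higher numbers for weaker inhibition of growth
compound 2 `Cc1cc(S(=O)(=O)Nc2nc3cc(-c4ccccc4)sc3c(=O)n2Cc2ccccc2)c(S)cc1Cl` gives > 100000 nM in this assay

The number for compound 2 is a limit of the assay, not a measured value. Compound 3 `Cc1cc(S(=O)(=O)Nc2nc3cc(-c4ccc(Cl)cc4)sc3c(=O)n2Cc2ccccc2)c(S)cc1Cl` differs from compound 2 by chloro in place of hydrogen on an aromatic carbon. Going by the values given here, the only measured step, an at least 7.0-fold higher number from compound 1 to compound 2 (0.84 log units; beyond the scatter), runs toward weaker inhibition and ends at the limit, as the limit of > 100000 nM in this assay, at which 1 of the 2 values shown sits, shows; it concerns a different change and gives no direct guide to the chloro. Compound 3 is therefore expected to remain at or beyond that limit, with a step that the limit leaves unreadable from compound 2 to compound 3 estimated as small. The estimate for compound 3 is 150000 nM, between 40000 nM and 600000 nM.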

Compound 3, concentration for 50% growth inhibition: > 100000 nM
Compound 3: a limit, no number; the forecaster's own chance of this, stated with the estimate: 85%; the middle value is on the limit's open side.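

Putting 4-chlorophenyl in place of hydrogen on the aromatic carbon gives an at least 7.0-fold higher number from compound 1 to compound 3 (0.84 log units; beyond the scatter) in this assay, so the weaker inhibition now holds for a second group at this position, not for phenyl alone. Compound 3 sits at a limit of the assay, not at a number. The change from phenyl to 4-chlorophenyl cannot be read, because both compounds stop at that limit: the limit of > 100000 nM in this assay, at which 2 of the 3 values shown sit.

On these data alone, what a methyl at this position would do remains open. So does whether an amine or a carboxylic acid on the phenyl would bring a measurable number.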